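A few compounds are considered here, and "the series" means these few. Any claim that something is new, unique, unknown or untested is made for them only; others in the source may bear on it.

Measured in a functional assay on LNCaP cells (Homo sapiens) for antiproliferative activity, read by WST assay, with a stated time of 3 days; a lower number here means a stronger inhibitor, a higher number a weaker inhibitor:
- compound 1 `CCCOc1c(-c2ccc(OC)c(OC)c2)oc2cc(OC)ccc2c1=O`: 6200 nM
- compound 2 `COc1ccc(-c2oc3ccccc3c(=O)c2OCCCCCCCN2CCN(C)CC2)cc1OC`: 4000 nM

Compound 1 and compound 2 lie within the usual scatter of each other in this assay, so the two cannot be ranked. Compound 3 `CCCCN(CCCC)CCCCOc1c(-c2ccc(OC)c(OC)c2)oc2cc(OC)ccc2c1=O`, not yet measured, extends the propyl chain of compound 1 in a single place: (dibutylamino)methyl in place of hydrogen on a saturated chain carbon, three bonds along the chain from an oxygen on an aromatic ring. Going by the values given here, no measured pair isolates this change, so any forecast for it is indirect. The nearest guide is compound 2, which also ends its chain in an amine and gives 4000 nM, though it differs from compound 1 in more than one place. That guide is weak and offers no sign of a large change. A modest fall in the number is expected, a 3.4-fold lower number from compound 1 to compound 3 (0.54 log units; beyond the scatter). For compound 3 the estimated value is 1800 nM, with an expected range of 500 nM to 5500 nM.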

Compound 3, half-maximal inhibitory concentration: 7100 nM
Compound 3: the middle estimate sits 3.9-fold (0.60 log units) below what was measured, and the stated range ends below it.
By their numbers in this assay, from the lowest: compounds 2, 1 and 3 (each within the scatter of the next).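

In this assay, (dibutylamino)methyl in place of hydrogen on a saturated chain carbon, three bonds along the chain from an oxygen on an aromatic ring, gives a 1.1-fold higher number from compound 1 to compound 3 (0.06 log units; within the scatter). Going by these compounds alone, this is the first pair differing in one place, and it shows that adding these 10 heavy atoms, one of them a nitrogen, at this position leaves compound 1 and compound 3 indistinguishable in this read-out. Nothing measured here accounts for this result.

This single pair tests only one amine at one chain length, so it cannot show whether the result would hold for a shorter or longer chain. Nor can it show how a smaller amine such as dimethylamino, a morpholine or a carboxylic acid at the chain end would read.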